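This account rests on a few compounds, and the source may have more. Where it says the series, first, only, none or still open, it means among the compounds named here.

Three compounds of this series have readings in a physicochemical assay for solubility, read by turbidimetry, measured as kinetic solubility, at pH 6.8; on this read-out higher numbers stand for higher solubility and lower numbers for lower solubility. Compound 1 `O=C(NCCCCn1cccn1)c1cccc(C2SCC(=O)N2c2ccccn2)c1` gives 50000 nM in this assay. Compound 2 `C#Cc1cccc(N2C(=O)CSC2c2cccc(C(=O)NCCCCc3ccccc3)c2)c1` gives 10000 nM in this assay, and compound 3 `COc1ccccc1N1C(=O)CSC1c1cc(F)cc(C(=O)NCCCCc2ccccc2)c1` gives 10000 nM in this assay. Compound 2 stands level with compound 3 at the digits shown, the two together the lowest of the three numbers; its nearest neighbour is compound 3, within the scatter, and compound 1 lies furthest, with the higher number beyond the scatter. Compound 4 `O=C(NCCCCc1ccccc1)c1cccc(C2SCC(=O)N2c2ccccc2F)c1` is not yet measured and differs from compound 2 in one place: 2-fluorophenyl in place of 3-ethynylphenyl on an amide-type nitrogen in a ring. Within the data shown here, no step between measured compounds covers this change. The expected step is small, upward if anything: a 1.5-fold higher number from compound 2 to compound 4 (0.18 log units; within the scatter). Compound 4 is therefore estimated at 15000 nM, with a range from 6000 nM to 40000 nM.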

Compound 4, solubility: 20000 nM
Compound 4: the middle estimate sits 1.3-fold (0.12 log units) below what was measured; the range from low to high includes it.
By their numbers in this assay, from the lowest: compounds 2, 3 and 4 (each within the scatter of the next); then compound 1.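

In this assay, among these compounds, the first one-place comparison, 2-fluorophenyl in place of 3-ethynylphenyl on the amide-type nitrogen in a ring, gives a 2.0-fold higher number from compound 2 to compound 4 (0.30 log units; within the scatter) at this position. This exchange of one carbon-only aromatic ring for another therefore cannot be told apart from the scatter of repeated measurements. Nothing available accounts for this reading. Open, on these data alone, is whether an amine or a carboxylic acid on this nitrogen, in place of the aromatic ring, would give a step beyond the scatter.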